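Cyclohexyl ammonium chain on the fluorophenyl core

The compounds below may be only part of what the source reports. "The series", "measured", "known", "first", "only" and "open" are said of these compounds alone.

Measured compounds:
- compound 1 `CN(C)c1ccc2c(=O)c(C(=O)Nc3cc(F)cc(F)c3)cn(-c3ccc(OCCCCCCC[n+]4ccccc4)cc3F)c2n1`: 15.4%
- compound 2 `Cc1cc(OCCCCCCC[N+](C)(C)C2CCCCC2)ccc1-n1cc(C(=O)Nc2cc(F)cc(F)c2)c(=O)c2ccc(N(C)C)nc21`: "not active" (no number reported)

In an assay on LX2 cells for inhibition of COL1A1 promoter (Homo sapiens), read by a luciferase reporter, with a stated time of 24 h, tested at 20 uM (on this read-out lower numbers stand for a weaker effect and higher numbers for a stronger effect at the one concentration tested), compound 1 gives 15.4%, a weak effect at the one concentration tested. In this assay compound 2 is reported as "not active" (no number reported), with no number given, so compound 2 stands without a value on the scale and cannot be placed relative to compound 1 beyond the remark that both are weak.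

Compound 3 `CN(C)c1ccc2c(=O)c(C(=O)Nc3cc(F)cc(F)c3)cn(-c3ccc(OCCCCCCC[N+](C)(C)C4CCCCC4)cc3F)c2n1` is not yet measured. It differs from compound 2 by fluoro in place of methyl on an aromatic carbon. For the measured compounds named here, no step between measured compounds is available to calibrate this change. The expected step in this assay from compound 2 to compound 3 is none beyond the usual scatter, given that compound 2 shows no activity and the change is a single atom.

Compound 3 is expected to give about 8% in this assay, within the range -8% to 25%, with a fair chance that only "not active" is reported.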

Compound 3, a percentage reported as inhibition, at one concentration (the size of the read-out at that concentration, not a potency): "not active" (no number reported)
Compound 3 has no reported number here, and the estimate cannot be compared.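

In this assay, for the compounds shown here, compound 2 and compound 3 both stand without a number, so no step from methyl to fluoro can be read. The compounds shown leave open whether this exchange changes the read-out at all. No supporting data bear on this result.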